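Methylamino amide in place of morpholine amide on the shared core

This account rests on a few compounds, and the source may have more. Where it says the series, first, only, none or still open, it means among the compounds named here.

Of the compounds shown here, three have been measured in an assay on a protein complex for inhibition of CDK8/Cyclin C (Homo sapiens), with a stated time of 1 h; on this read-out higher numbers stand for weaker inhibition and lower numbers for stronger inhibition. Compound 1 `CCOC(=O)/C=C/c1ccncc1-c1ccc2c(ccn2C)c1` gives 144 nM. Compound 2 `CNC(=O)/C=C/c1ccncc1-c1ccc2[nH]ccc2c1` gives 51.9 nM. Compound 3 `Cn1ccc2cc(-c3cnccc3/C=C/C(=O)N3CCOCC3)ccc21` gives 247 nM, the highest of the three numbers; its gap to compound 1 is within the scatter, its gap to compound 2 is beyond it.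

The next step goes from compound 3 to compound 4 `CNC(=O)/C=C/c1ccncc1-c1ccc2c(ccn2C)c1`. The change is methylamino in place of morpholin-4-yl on a carbonyl carbon.

For the measured compounds named here, of the measured steps, only the one from compound 1 to compound 3 touches the same carbonyl carbon: a 1.7-fold higher number from compound 1 to compound 3 (0.23 log units; within the scatter), a change that stayed within the scatter. Going by the values given here, compound 2 carries the methylcarbamoyl group of compound 4 but differs from it elsewhere in the molecule, so no single step connects them; its value sits well below that of compound 3. Taken together, the replacements at this carbonyl carbon have so far moved the numbers little, while the one compound bearing methylcarbamoyl gives the lowest number of the set. For compound 4 a move towards lower numbers in this assay is therefore expected, a 2.5-fold lower number from compound 3 to compound 4 (0.39 log units; beyond the scatter), of a size that may reach beyond the scatter. Compound 4 is estimated at 100 nM, with a range from 40 nM to 250 nM.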

Compound 4, half-maximal inhibitory concentration: 77.6 nM
Compound 4: the middle estimate sits 1.3-fold (0.11 log units) above what was measured, and the stated range covers the measured number.
By their numbers in this assay, from the lowest: compounds 2, 4, 1 and 3 (each within the scatter of the next, the first and the last beyond it).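

In this assay, the change at this carbonyl carbon now produces a step beyond the scatter, with methylamino in place of morpholin-4-yl giving a 3.2-fold lower number from compound 3 to compound 4 (0.50 log units; beyond the scatter). For the compounds shown here, the earlier step at the same carbon, morpholin-4-yl in place of ethoxy, stayed within the scatter, and ethoxy and methylamino cannot be told apart on the core of compound 1 either (a 1.9-fold lower number from compound 1 to compound 4 (0.27 log units; within the scatter)), so morpholin-4-yl is the only group that separates from methylamino here, and only modestly. The methyl on the aromatic nitrogen also stays within the scatter (a 1.5-fold higher number from compound 2 to compound 4 (0.17 log units; within the scatter)), so with methylcarbamoyl in place this methyl shows no readable effect in this assay.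

No supporting measurement accounts for the step from compound 3 to compound 4. That step removes a six-membered ring, reduces the heavy atoms and adds a hydrogen-bond donor all at once, and the compounds shown cannot separate these changes; dimethylamino or ethylamino on the same carbonyl carbon, or a carboxylic acid there, would give further readings of this position.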